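From nitro to amino in the series

The source may report more compounds than this note shows. Statements on the series, on what has been measured and on what is new or still open speak of the compounds shown alone.

Measured in a functional assay on A2780 cells (Homo sapiens) for cytotoxicity, read by MTT assay, with a stated time of 48 h; a higher number here means a weaker inhibitor, a lower number a stronger inhibitor:
- compound 1 `CCn1cc(-c2nc3ccccc3s2)c(=O)c2cc(F)c(N3CCNCC3)nc21`: 2700 nM
- compound 2 `CCn1cc(-c2nc3ccc([N+](=O)[O-])cc3[nH]2)c(=O)c2cc(F)c(N3CCNCC3)nc21`: 12400 nM

Compound 2, at 12400 nM, holds the higher of the two numbers, and its gap to compound 1 lies beyond the scatter. Within the data shown here, these two compounds differ in more than one place, so no single-change step is available as a guide.

Compound 3 `CCn1cc(-c2nc3ccc(N)cc3[nH]2)c(=O)c2cc(F)c(N3CCNCC3)nc21` differs from compound 2 by amino in place of nitro on an aromatic carbon. Among the measured compounds shown here, no measured compound shows the size of this change, so any expectation is loose. For the measured compounds named here, the only pointer is that compound 1, which has no nitro, gives 2700 nM. In this assay, a modest step to a lower number, little beyond the scatter, is expected. The estimated change is a 2.3-fold lower number from compound 2 to compound 3 (0.35 log units; beyond the scatter). Compound 3 is expected at 5500 nM, with an estimated range of 1800 nM to 17000 nM.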

Compound 3, half-maximal inhibitory concentration: 42300 nM
Estimate against measurement, compound 3: 7.7-fold (0.89 log units) below, outside the stated range (above it).
By their numbers in this assay, from the lowest: compound 1; then compound 2; then compound 3.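

On this aromatic carbon, in this assay, amino in place of nitro gives a 3.4-fold higher number from compound 2 to compound 3 (0.53 log units; beyond the scatter), so losing the nitro does not by itself lower the number here. The amino compound ends up as the weakest of the three, with a 16-fold higher number from compound 1 to compound 3 (1.19 log units; beyond the scatter), although that step exchanges the whole fused group and not just one substituent. No measurement available on the series accounts for the direction of the nitro-to-amino step.

Still open, from the compounds shown here alone, is whether nitro and amino mark a trend at this position or are two isolated points: a hydroxyl, a methoxy or an acetamide on the same carbon would test this. Also open, going by these compounds, is how much of the gap to compound 1 belongs to the fused group and how much to the amino.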